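Shifting the aryl substituent on a dihydropyridine-type ester

The source may report more compounds than this note shows. Statements on the series, on what has been measured and on what is new or still open speak of the compounds shown alone.

The set rests on a shared core, varied only in the aryl group on the saturated ring carbon. Compound 1 `COC(=O)C1=C(C)N=C(C)/C(=C(\O)OC)C1c1ccc(Cl)cc1` carries a 4-chlorophenyl group and, in a functional assay (muscle tissue) with Cavia porcellus as the target (on this read-out higher numbers stand for an effect only at larger amounts of compound and lower numbers for an effect already at smaller amounts), compound 1 gives 8130 nM. Compound 2 `COC(=O)C1=C(C)N=C(C)/C(=C(\O)OC)C1c1ccc(F)cc1` carries a 4-fluorophenyl group instead; in this assay compound 2 gives 129 nM, the second highest of the three numbers, and the change a 63-fold lower number from compound 1 to compound 2 (1.80 log units; beyond the scatter). Within the data shown here, compound 3 `COC(=O)C1=C(C)N=C(C)/C(=C(/O)OC)C1c1cccc(Cl)c1` carries a 3-chlorophenyl group and gives 15.9 nM, the lowest number of the three; no single-point step links it to compound 1, but the two values show a wide gap between them.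

Compound 4 `COC(=O)C1=C(C)N=C(C)/C(=C(\O)OC)C1c1cccc(C#N)c1` is the unmeasured member. Relative to compound 2 the change is 3-cyanophenyl in place of 4-fluorophenyl on a saturated ring carbon. Among the measured compounds shown here, no measured step covers this exact change. For the measured compounds named here, the one step at this position, from chloro to fluoro, was large, and compound 3 with a 3-substituted ring gave the lowest number. Compound 4 is therefore expected to show a 4.3-fold lower number from compound 2 to compound 4 (0.63 log units; beyond the scatter), giving an estimated 30 nM, within 5 nM to 300 nM.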

Compound 4, half-maximal effective concentration: 34.7 nM
Beside the measured number, compound 4's estimate is 1.2-fold (0.06 log units) below it; measured number inside the range.
By their numbers in this assay, from the lowest: compound 3; then compound 4; then compound 2; then compound 1.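

In this assay, placing 3-cyanophenyl on the saturated ring carbon gives a 3.7-fold lower number from compound 2 to compound 4 (0.57 log units; beyond the scatter) and a 230-fold lower number from compound 1 to compound 4 (2.37 log units; beyond the scatter). The position therefore tolerates more than a halogen on the aryl ring: a group with a triple bond and a hydrogen-bond acceptor, which 4-fluorophenyl lacks, still leaves the number well below those of the two 4-substituted compounds. Nothing available here explains either step.

Each step changes the substituent and its place on the phenyl ring together, so the contribution of the nitrile cannot be separated from that of its ring position. As far as these compounds go, how 4-cyanophenyl would read remains open, as does the effect of an amine or a carboxylic acid in place of the nitrile.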